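Benzothiophene ketones with trimethoxybenzoyl: changing the aryl partner

A few compounds are considered here, and "the series" means these few. Any claim that something is new, unique, unknown or untested is made for them only; others in the source may bear on it.

Compound 1 `COc1cc(C(=O)c2sc3ccccc3c2-c2ccc(C)cc2)cc(OC)c1OC`: 3500 nM
Compound 2 `COc1cc(C(=O)c2sc3ccccc3c2-c2ccc(SC)cc2)cc(OC)c1OC`: 1800 nM
Compound 3 `COc1ccc(OC)c(-c2c(C(=O)c3cc(OC)c(OC)c(OC)c3)sc3ccccc23)c1`: > 10000 nM

All three compounds share a core that carries a trimethoxybenzoyl group and were tested in a functional assay on K562 cells (Homo sapiens) for antiproliferative activity, read by MTT assay, with a stated time of 72 h; on this read-out lower numbers stand for stronger inhibition and higher numbers for weaker inhibition. Compound 1 gives 3500 nM and compound 2 gives 1800 nM; the step of a 1.9-fold lower number from compound 1 to compound 2 (0.29 log units; within the scatter) is within the scatter. Compound 3 stands apart: in this assay its value of > 10000 nM is a limit of the assay and not a number (the limit of > 10000 nM in this assay, at which 1 of the 3 values shown sits). Relative to the other two it shows an at least 2.8-fold higher number from compound 1 to compound 3 (0.45 log units; beyond the scatter) and an at least 5.5-fold higher number from compound 2 to compound 3 (0.74 log units; beyond the scatter), so the 2,5-dimethoxyphenyl group is linked to the weakest result among the three.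

Compound 4 `CCOc1ccc(Nc2c(C(=O)c3cc(OC)c(OC)c(OC)c3)sc3ccccc23)cc1` has not yet been measured. It differs from compound 3 in one place: (4-ethoxyphenyl)amino in place of 2,5-dimethoxyphenyl on an aromatic carbon. Going by the values given here, no measured step covers a (4-ethoxyphenyl)amino group on this carbon, so the expectation rests on the comparison with compounds 1 and 2, whose groups at this position are linked to lower numbers than that of compound 3. The step from compound 3 to compound 4 is expected to be an at least 4.0-fold lower number from compound 3 to compound 4 (0.60 log units; beyond the scatter), toward a lower number. Compound 4 is therefore expected at 2500 nM, with a range from 400 nM to 15000 nM.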

Compound 4, half-maximal inhibitory concentration: 200 nM
For compound 4 the middle estimate is 13-fold (1.10 log units) above the measured one; measured number outside the range, below it.
By their numbers in this assay, from the lowest: compound 4; then compounds 2 and 1 (each within the scatter of the next). At a limit, above all of these: compound 3.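

With the (4-ethoxyphenyl)amino group on this aromatic carbon, two ring bonds from the ring sulfur, the result moves well beyond anything the three aryl groups showed, with an at least 50-fold lower number from compound 3 to compound 4 (1.69 log units; beyond the scatter). Going by these compounds alone, the same group also separates compound 4 clearly from the two compounds with a 4-substituted phenyl group, with a 9.0-fold lower number from compound 2 to compound 4 (0.95 log units; beyond the scatter) and an 18-fold lower number from compound 1 to compound 4 (1.24 log units; beyond the scatter), so this position can give a far lower number than the earlier compounds suggested, and compound 4 is the most potent of the four in this assay. The first of these steps has only a lower bound, since compound 3 gives > 10000 nM, which is a limit of the assay and not a number: the limit of > 10000 nM in this assay, at which 1 of the 4 values shown sits.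

The compounds shown do not separate the contribution of the amine nitrogen, which carries the one hydrogen-bond donor that enters with this group, from that of the ethoxy group on the phenyl ring. A (4-methoxyphenyl)amino or plain phenylamino group, or a 4-ethoxyphenyl group joined through an ether oxygen or a methylene, would be needed to tell these two parts apart.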